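Thiophene carboxamide series: the thiourea aryl substituent

This account rests on a few compounds, and the source may have more. Where it says the series, first, only, none or still open, it means among the compounds named here.

Measured so far in a functional assay on HeLa cells (Homo sapiens) for antiproliferative activity, with a stated time of 24 h; a higher number here means a weaker inhibitor, a lower number a stronger inhibitor:
compound 1, `NC(=O)c1c(NC(=O)c2ccccc2Cl)sc2c1CCN(Cc1ccc(Cl)cc1Cl)C2`, 21100 nM
compound 2, `NC(=O)c1c(NC(=O)c2ccccc2Cl)sc2c1CCN(C(=O)Nc1ccccc1Cl)C2`, 45400 nM
compound 3, `NC(=O)c1c(NC(=O)c2ccccc2Cl)sc2c1CCN(C(=S)Nc1ccccc1Br)C2`, 24600 nM

Compound 3 gives the second highest of the three numbers in this assay. Its nearest neighbour is compound 1, a step within the scatter (a 1.2-fold higher number from compound 1 to compound 3 (0.07 log units; within the scatter)); its furthest is compound 2, also within the scatter (a 1.8-fold lower number from compound 2 to compound 3 (0.27 log units; within the scatter)). For the measured compounds named here, only one step in the set is beyond the scatter, the modest one a 2.2-fold higher number from compound 1 to compound 2 (0.33 log units; beyond the scatter).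

Compound 4, `COc1ccccc1NC(=S)N1CCc2c(sc(NC(=O)c3ccccc3Cl)c2C(N)=O)C1`, differs from compound 3 at the aryl ring on the thiourea: methoxy in place of bromo on an aromatic carbon. Going by the values given here, none of the measured steps changes a substituent on that ring while leaving the rest of the molecule fixed; the steps that touch the ring amine nitrogen exchange the whole group, and two of the three stay within the scatter. Replacing the substituent alone is a smaller change than any of those, so no step beyond the scatter is expected in this assay, in either direction.

Compound 4 is therefore estimated at 25000 nM, range 10000 nM to 60000 nM, an expected step of a 1.0-fold higher number from compound 3 to compound 4 (0.01 log units; within the scatter).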

Compound 4, half-maximal inhibitory concentration: > 50000 nM
Compound 4: a limit, no number (the forecaster's own chance of this, stated with the estimate: 15%); middle value at least 2.0-fold (0.30 log units) from the limit.
By their numbers in this assay, from the lowest: compounds 1, 3 and 2 (each within the scatter of the next, the first and the last beyond it). At a limit, above all of these: compound 4.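

In this assay compound 4 stands at a limit of the assay and not at a number: the limit of > 50000 nM in this assay, at which 1 of the 4 values shown sits. Methoxy in place of bromo on an aromatic carbon, ortho to a large group, is the only step shown that alters this substituent and leaves the rest of the molecule fixed, and it reads an at least 2.0-fold higher number from compound 3 to compound 4 (0.30 log units; that floor lies within the scatter), so this change brings no gain in this assay, while a real loss is not established by its floor alone. Of the other two new steps, an at least 1.1-fold higher number from compound 2 to compound 4 (0.04 log units; that floor lies within the scatter) also has its floor within the scatter, whereas an at least 2.3-fold higher number from compound 1 to compound 4 (0.37 log units; beyond the scatter) is the only one beyond it.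

With just bromo and methoxy at this place, the compounds shown give neither a trend across substituents nor a cause for the step, and the limit leaves open how far compound 4 actually lies from the others. Also open, on these data alone, is how a methyl, a hydroxyl or an amine on the same aromatic carbon would read in this assay, and whether methoxy would read the same on the urea of compound 2.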